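The source may hold more compounds than are shown below. What is called first, only, known or untested is meant among the compounds shown, and "the series" means these compounds.

Working notes on the series. Within the data shown here, in an assay on HEK293 cells for activation of Kir3.1/Kir3.2 (Homo sapiens), read by thallium flux (a higher number here means a larger maximal response, a lower number a smaller maximal response), compound 2 `Cc1ccc(-c2nnn(CC(=O)Nc3cc(C)nn3C3CCCCC3)n2)cc1` gives 86%, the lowest of the two numbers so far; its nearest neighbour is compound 1 `Cc1cc(NC(=O)Cn2nnc(-c3cccnc3)n2)n(C2CCCCC2)n1`, which in this assay gives 96%, the step being a number 10 percentage points lower from compound 1 to compound 2 (within the scatter). Compound 3 `Cc1cc(NC(=O)Cn2nnc(-c3ccc(Cl)c(C)c3)n2)n(C2CCCCC2)n1` differs from compound 2 by 4-chloro-3-methylphenyl in place of 4-methylphenyl on an aromatic carbon. Among the measured compounds shown here, the only measured step at this place, a number 10 percentage points lower from compound 1 to compound 2 (within the scatter), stayed within the scatter, so no change beyond the scatter is expected in this assay for this further exchange at the same aromatic carbon. Compound 3 is therefore expected to give 86%, within 70% to 100%. The expected step is no change at the digits printed from compound 2 to compound 3 (within the scatter).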

Compound 3, largest response reached (Emax), in percent of the reference or control that the assay uses: 89%
The estimate for compound 3 lay 3 percentage points below the measured number; the range from low to high includes it.
By their numbers in this assay, from the lowest: compounds 2, 3 and 1 (each within the scatter of the next).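

In this assay, 4-chloro-3-methylphenyl in place of 4-methylphenyl gives a number 3 percentage points higher from compound 2 to compound 3 (within the scatter), and in place of pyridin-3-yl it gives a number 7 percentage points lower from compound 1 to compound 3 (within the scatter). A chlorine-bearing phenyl at this aromatic carbon therefore reads the same as the two earlier aromatic rings, and all three compounds stand within the scatter of each other. Nothing available bears on the reason for this. Still open, on these data alone, is whether a group without an aromatic ring, such as an amine or a carboxylic acid, would keep the response at this aromatic carbon.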